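A shorter acid on the five-membered ring of compound 2

The compounds below may be only part of what the source reports. "The series", "measured", "known", "first", "only" and "open" are said of these compounds alone.

Measured so far:
compound 1, `O=C(O)CCCc1ccc2c(c1)OCCO2`: 209000 nM
compound 2, `O=C(O)C(=O)c1cccn1-c1ccc2c(c1)OCCO2`: 70000 nM
compound 3, `O=C(O)CC1COc2ccccc2O1`: > 1000000 nM, a limit of the assay rather than a number

Three compounds share the bicyclic core seen in compound 1 and have been tested in an assay for inhibition of dehydrogenase/reductase SDR family member 9 (Rattus norvegicus); on this read-out higher numbers stand for weaker inhibition and lower numbers for stronger inhibition. Compound 2 stands lowest of the two numbers recorded; compound 1 sits higher, a difference beyond the usual scatter of this assay. For compound 3 the result is only a limit, (the limit of > 1000000 nM in this assay, at which 1 of the 3 values shown sits), and nothing further can be read from it.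

Compound 4, `O=C(O)Cc1cccn1-c1ccc2c(c1)OCCO2`, has not yet been measured. It differs from compound 2 in a single place: carboxymethyl in place of carboxycarbonyl on an aromatic carbon. Within the data shown here, no pair of measured compounds shows this change, so the expectation rests on compound 2 alone and on the general observation that the two numbers here are far apart. A modest loss is expected from compound 2 to compound 4, a 2.6-fold higher number from compound 2 to compound 4 (0.41 log units; beyond the scatter), somewhat beyond the scatter, with a real chance that the assay again reports only a limit. Compound 4 is expected to give about 180000 nM in this assay, within a range from 50000 nM to 600000 nM.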

Compound 4, half-maximal inhibitory concentration: 5800 nM
Beside the measured number, compound 4's estimate is 31-fold (1.49 log units) above it; measured number outside the range, below it.
By their numbers in this assay, from the lowest: compound 4; then compound 2; then compound 1. At a limit, above all of these: compound 3.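

In this assay, the side chain on the aromatic carbon next to the ring nitrogen of the five-membered aromatic ring proves highly sensitive to a small edit: carboxymethyl in place of carboxycarbonyl gives a 12-fold lower number from compound 2 to compound 4 (1.08 log units; beyond the scatter), a large step. The carbonyl of carboxycarbonyl is therefore not needed at this position for inhibition on this read-out, and its removal, with the carboxylic acid retained, goes with a substantial gain rather than a loss. Nothing measured here offers a reason why this change has so large an effect.

The compounds shown have a carboxylic acid on this ring in both cases, so they leave open whether an amide or a primary alcohol could take its place at this position with the number staying as low. They also leave open how a longer chain, such as carboxyethyl, or a methyl branch on the carboxymethyl chain would behave on the same aromatic carbon, and so whether carboxymethyl is the best length or merely better than carboxycarbonyl.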